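The source may hold more compounds than are shown below. What is called first, only, known or untested is meant among the compounds shown, and "the series" means these compounds.

Compound 1 `O=C(/C=C\c1ccccc1O)N1N=C(c2ccncc2)OC1c1c[nH]c2ccccc12` stands only at a limit in an ADME assay on A549 cells (Homo sapiens) for cytotoxicity, read by MTT assay, with a stated time of 48 h (on this read-out lower numbers stand for stronger inhibition of growth and higher numbers for weaker inhibition of growth), where compound 1 gives > 30 ug/mL. Compound 2 `O=C(/C=C\c1ccc(O)cc1)N1N=C(c2ccncc2)OC1c1c[nH]c2ccccc12` is in the same position in this assay, since compound 2 gives > 30 ug/mL, also a limit. Hence a step that the two limits leave unreadable from compound 1 to compound 2. Compound 3 `O=C(/C=C\c1ccc(Cl)cc1Cl)N1N=C(c2ccncc2)OC1c1c[nH]c2ccccc12` differs from compound 1 by 2,4-dichlorophenyl in place of 2-hydroxyphenyl on a double-bonded chain carbon bound to a double-bonded chain carbon. Within the data shown here, the only bearing evidence is the limit of > 30 ug/mL in this assay, at which 2 of the 2 values shown sit, which leaves the effect of this change unread. Compound 3 is therefore expected to show a number no higher from compound 1 to compound 3 (the limit leaves the size open), most likely again a limit. The estimate for compound 3 in this assay is 30 ug/mL, within 8 ug/mL to 100 ug/mL.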

Compound 3, concentration for 50% growth inhibition: > 30 ug/mL
Compound 3 ended at the assay's limit; the forecaster's own chance of this, stated with the estimate: 60%; the middle value lies on the limit itself.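

Compound 3 also stands at a limit in this assay, so no step among compound 1, compound 2 and compound 3 can be read: the limit of > 30 ug/mL in this assay, at which 3 of the 3 values shown sit.

The compounds shown leave open whether 2-hydroxyphenyl, 4-hydroxyphenyl and 2,4-dichlorophenyl differ in their effect on growth inhibition.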